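The source may report more compounds than this note shows. Statements on the series, on what has been measured and on what is new or still open speak of the compounds shown alone.

Compound 1 `Cc1c(O)nc(SCc2ccc(Cl)cc2)nc1Cc1c(Cl)cccc1Cl` was tested in a functional assay on MT4 cells (Homo sapiens) for cytotoxicity, read by MTT assay; a higher number here means that more compound is tolerated, a lower number that less compound is tolerated. Compound 1 gives > 59000 nM, which is a limit of the assay rather than a number. Two related compounds were tested the same way. Compound 2 `COc1ccc(CCSc2nc(Cc3c(Cl)cccc3Cl)c(C)c(=O)[nH]2)cc1` gives > 57000 nM, again a limit of the assay. Compound 3 `COc1ccc(CSc2nc(O)c(C)c(Cc3c(Cl)cccc3Cl)n2)cc1OC` gives > 55000 nM, also a limit of the assay. So nothing is known of compound 1 beyond its limit, and the same holds for the other two: all three sit at a limit, as in the limit of > 59000 nM in this assay, at which 1 of the 3 values shown sits, the limit of > 57000 nM in this assay, at which 1 of the 3 values shown sits, and (the limit of > 55000 nM in this assay, at which 1 of the 3 values shown sits). Among the measured compounds shown here, no step between measured compounds can be given, since none of them returns a number.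

The compound still to be measured is compound 4 `Cc1c(O)nc(SCc2ccc(C#N)cc2)nc1Cc1c(Cl)cccc1Cl`. Set against compound 1 it differs in one place: cyano in place of chloro on an aromatic carbon The shared core and the rest of the molecule are unchanged.

With only limits to go on, and all three of them at about the same level, the expectation for compound 4 in this assay is that it too will reach the top of the tested range without reading out a number. The step that the limit leaves unreadable from compound 1 to compound 4 is expected to be no larger than the scatter. Compound 4 is estimated at 60000 nM, within a range of 30000 nM to 120000 nM.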

Compound 4, half-maximal cytotoxic concentration: > 60000 nM
Compound 4 gave a limit, no number; the forecaster's own chance of this, stated with the estimate: 80%; the middle value sits exactly at the limit.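

Compound 1 and compound 4 both return only a limit of the assay, so no step can be read between them in this assay, and the change from chloro to cyano has no measurable size here. The compounds shown leave open what concentration, if any, would harm these cells, and whether the two groups differ in that respect.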